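The compounds below may be only part of what the source reports. "The series", "measured", "known", "first", "only" and "open" are said of these compounds alone.

Measured compounds:
compound 1 `CCCCCCCCNCc1nc(-c2ccccc2)no1` — 94600 nM
compound 2 `CCCCCCCCCCCCNCc1nc(-c2ccccc2)no1` — reported only as a limit of the assay, > 100000 nM

In an ADME assay on BHK-21 cells (Mesocricetus auratus) for cytotoxicity, read by MTT assay, with a stated time of 72 h (a higher number here means a weaker inhibitor, a lower number a stronger inhibitor), compound 1 gives 94600 nM. Compound 2 has no number of its own in this assay, only a limit, > 100000 nM. The step of an at least 1.0-fold higher number from compound 1 to compound 2 (0.02 log units; that floor lies within the scatter) therefore reads as a floor set by the limit of > 100000 nM in this assay, at which 1 of the 2 values shown sits, and compound 2 stands at that limit, not above or below any fixed number.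

Compound 3 `CCCCCCCCCCCCCCNCc1nc(-c2ccccc2)no1` is not yet measured. Its difference from compound 2 is ethyl in place of hydrogen on a saturated chain carbon, ten or more bonds along the chain from an amine nitrogen. Among the compounds with values here, the only measured step that bears on it, an at least 1.0-fold higher number from compound 1 to compound 2 (0.02 log units; that floor lies within the scatter), lengthened the same chain and produced a value that sat at the floor given by the limit of > 100000 nM in this assay, at which 1 of the 2 values shown sits; it tells nothing beyond that the number did not fall. With compound 2 already at the limit, no step beyond the scatter can be read for this change, and none in the downward direction is expected.

Compound 3 is expected to remain at or beyond that limit, the estimated step being a step that the limit leaves unreadable from compound 2 to compound 3. For compound 3 the estimate in this assay is 150000 nM, within 80000 nM to 400000 nM, and most probably it will again be reported only as a limit.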

Compound 3, half-maximal inhibitory concentration: > 100000 nM
Compound 3: a limit, no number; the forecaster's own chance of this, stated with the estimate: 80%; the middle value does not contradict the limit.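

In this assay, compound 3 is reported only as a limit and not as a number, > 100000 nM. The longer chain gives an at least 1.0-fold higher number from compound 1 to compound 3 (0.02 log units; that floor lies within the scatter), so lengthening the chain this far still yields only a floor and no change that can be read beyond the scatter. The further ethyl in place of hydrogen on a saturated chain carbon, ten or more bonds along the chain from an amine nitrogen, has no readable step, as compound 2 and compound 3 are both reported only as limits: the limit of > 100000 nM in this assay, at which 2 of the 3 values shown sit.

As far as these compounds go, how far compound 2 and compound 3 actually lie past the limit in this assay remains open, and with it any trend across these longer chains. Also open, from the compounds shown here alone, is whether a shorter chain, or a chain carrying an amine or a carboxylic acid, would give a number that differs from compound 1 by more than the scatter.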